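A few compounds are considered here, and "the series" means these few. Any claim that something is new, unique, unknown or untested is made for them only; others in the source may bear on it.

Compound 1 `Cc1nc(C(F)(F)F)ccc1CNC(=O)C(C)c1ccc(NS(C)(=O)=O)c(F)c1` carries a methyl on the aromatic carbon of its core. In an assay on CHO cells for antagonist activity at transient receptor potential cation channel subfamily V member 1 (Homo sapiens), read by FLIPR and calcium flux (on this read-out lower numbers stand for stronger inhibition and higher numbers for weaker inhibition), compound 1 gives 387 nM, the highest number among the three measured compounds. Compound 2 `CCC1CCC(c2nc(C(F)(F)F)ccc2CNC(=O)C(C)c2ccc(NS(C)(=O)=O)c(F)c2)CC1`, with a 4-ethylcyclohexyl at that position, gives 0.3 nM in this assay, and compound 3 `CC1C=C(c2nc(C(F)(F)F)ccc2CNC(=O)C(C)c2ccc(NS(C)(=O)=O)c(F)c2)CCC1`, with a 3-methylcyclohex-1-en-1-yl, gives 0.2 nM. The two steps from compound 1 are large: a 1300-fold lower number from compound 1 to compound 2 (3.11 log units; beyond the scatter) and a 1900-fold lower number from compound 1 to compound 3 (3.29 log units; beyond the scatter), while between the two ring groups there is only a 1.5-fold lower number from compound 2 to compound 3 (0.18 log units; within the scatter).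

Compound 4 `CC(C)=Cc1nc(C(F)(F)F)ccc1CNC(=O)C(C)c1ccc(NS(C)(=O)=O)c(F)c1` changes compound 1 as follows: 2-methylprop-1-en-1-yl in place of methyl on an aromatic carbon. The entering group is acyclic and smaller than the 4-ethylcyclohexyl or the 3-methylcyclohex-1-en-1-yl, yet it extends well beyond a methyl. Both measured steps from compound 1 bear on it and point the same way, so a drop beyond the scatter in this assay is expected, though a less complete one than either ring brought. The estimate for compound 4 is 10 nM, with a range from 2 nM to 60 nM, corresponding to an expected 39-fold lower number from compound 1 to compound 4 (1.59 log units; beyond the scatter).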

Compound 4, inhibition constant: 11.5 nM
Estimate against measurement, compound 4: 1.2-fold (0.06 log units) below; measured number inside the range.
By their numbers in this assay, from the lowest: compounds 3 and 2 (each within the scatter of the next); then compound 4; then compound 1.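

In this assay, a ring is not needed for a large step at this position next to the ring nitrogen: the acyclic 2-methylprop-1-en-1-yl brings a 34-fold lower number from compound 1 to compound 4 (1.53 log units; beyond the scatter) on its own. The two ring groups nevertheless remain well apart from it, with a 58-fold higher number from compound 3 to compound 4 (1.76 log units; beyond the scatter) and a 38-fold higher number from compound 2 to compound 4 (1.58 log units; beyond the scatter) as the further changes, so among these four compounds the numbers fall in stages as the methyl gives way to the open chain and then to the rings. Nothing given here accounts for this order. The compounds shown leave open whether the double bond of the 2-methylprop-1-en-1-yl matters, a question a saturated 2-methylpropyl group would address. They also leave open whether a longer open carbon chain could match the rings, and how a ring amine such as piperidine would fare here.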